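The source may report more compounds than this note shows. Statements on the series, on what has been measured and on what is new or still open speak of the compounds shown alone.

Measured so far:
- compound 1 `CCCSc1nc(N/N=C(\C)c2ccccc2O)c2nnn(Cc3ccc(Cl)cc3)c2n1`: in a functional assay on MGC-803 cells (Homo sapiens) for antiproliferative activity, read by MTT assay, with a stated time of 72 h (on this read-out higher numbers stand for weaker inhibition and lower numbers for stronger inhibition), compound 1 gives 7100 nM
- compound 3 `CCCSc1nc(N/N=C(\C)c2ccc(OC)cc2)c2nnn(Cc3ccccc3)c2n1`: compound 3 gives 44300 nM
- compound 2 `CCCSc1nc(N/N=C/c2ccc(C)cc2)c2nnn(Cc3ccccc3)c2n1`: compound 2 gives only > 64000 nM, which is a limit of the assay and not a number

Compound 2 therefore stands at the weak end of the three values, at the limit of > 64000 nM in this assay, at which 1 of the 3 values shown sits, and no number for it is available to compare against compound 1 or compound 3. Compound 4 `CCCSc1nc(N/N=C/c2c[nH]c3ccccc23)c2nnn(Cc3ccccc3)c2n1` is still to be measured in this assay. It differs from compound 2 in one place: 1H-indol-3-yl in place of 4-methylphenyl on a carbon with a double bond to nitrogen. No step between measured compounds tests this exchange, so its size rests on the other aryl hydrazones shown, where compound 1 and compound 3 give numbers below the limit. The exchange is expected to move the value downwards from the limit, by a moderate step, with wide uncertainty. The expected step is an at least 2.1-fold lower number from compound 2 to compound 4 (0.32 log units; beyond the scatter). Compound 4 is estimated at 30000 nM, with a range from 8000 nM to 100000 nM, and a fair chance that only a limit is reported again.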

Compound 4, half-maximal inhibitory concentration: 7410 nM
For compound 4 the middle estimate is 4.0-fold (0.61 log units) above the measured one, outside the stated range (below it).
By their numbers in this assay, from the lowest: compounds 1 and 4 (each within the scatter of the next); then compound 3. At a limit, above all of these: compound 2.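

In this assay, 1H-indol-3-yl in place of 4-methylphenyl on a carbon with a double bond to nitrogen gives an at least 8.6-fold lower number from compound 2 to compound 4 (0.93 log units; beyond the scatter). Among these compounds, this is the first exchange made in one place with the rest of the molecule unchanged, so it shows that the aryl group on this carbon alone can move the read-out beyond the scatter. Compound 2 sits at a limit of the assay and not at a number, so the step fixes only a minimum size: the limit of > 64000 nM in this assay, at which 1 of the 4 values shown sits.

A naphthyl group on this carbon would separate the added ring of 1H-indol-3-yl from its hydrogen-bond donor, and the compounds shown leave open which of the two goes with the lower number. Also open, as far as these compounds go, is whether the same exchange gives a comparable step on the core of compound 3.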